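The source may hold more compounds than are shown below. What is called first, only, known or untested is meant among the compounds shown, and "the series" means these compounds.

Three compounds that share one core and differ only in the group on the sulfonamide nitrogen have been measured in a functional assay on K562 cells (Homo sapiens) for antiproliferative activity, read by sulforhodamine B assay, with a stated time of 48 h; a lower number here means a stronger inhibitor, a higher number a weaker inhibitor. Compound 1 (`CCc1cccc(NS(=O)(=O)c2ccc(N3CCNC3=O)cc2)c1`) carries 3-ethylphenyl and gives 230 nM. Compound 2 (`O=C1NCCN1c1ccc(S(=O)(=O)Nc2cccc(Br)c2)cc1`) carries 3-bromophenyl and gives 87 nM. Compound 3 (`Cc1cc(C)cc(NS(=O)(=O)c2ccc(N3CCNC3=O)cc2)c1`) carries 3,5-dimethylphenyl and gives 110 nM. This value cannot be told apart from that of compound 2, as the step is a 1.3-fold higher number from compound 2 to compound 3 (0.10 log units; within the scatter). It does stand apart from compound 1, though only modestly, with a 2.1-fold lower number from compound 1 to compound 3 (0.32 log units; beyond the scatter).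

Compound 4 (`O=C1NCCN1c1ccc(S(=O)(=O)Nc2cccc(Cl)c2)cc1`) has not yet been measured. It has 3-chlorophenyl in place of 3,5-dimethylphenyl on a sulfonamide nitrogen. The closest guide is compound 2, whose 3-bromophenyl group also holds a single halogen atom on the ring. The other bearing step is a 2.6-fold lower number from compound 1 to compound 2 (0.42 log units; beyond the scatter), which is also modest. Among the compounds with values here, no measured compound yet carries chlorine, so this comparison remains indirect. No step beyond the scatter is expected in this assay, because a 1.3-fold higher number from compound 2 to compound 3 (0.10 log units; within the scatter) shows the bromo compound and compound 3 sitting together. The expected change is a 1.1-fold lower number from compound 3 to compound 4 (0.04 log units; within the scatter). For compound 4 the estimated value is 100 nM, with an expected range from 50 nM to 200 nM.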

Compound 4, half-maximal inhibitory concentration: 69 nM
Estimate against measurement, compound 4: 1.4-fold (0.16 log units) above; measured number inside the range.
By their numbers in this assay, from the lowest: compounds 4, 2 and 3 (each within the scatter of the next); then compound 1.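

In this assay a second halogen now sits on the ring attached to the sulfonamide nitrogen, and the result joins the earlier group: a 1.3-fold lower number from compound 2 to compound 4 (0.10 log units; within the scatter) and a 1.6-fold lower number from compound 3 to compound 4 (0.20 log units; within the scatter) are both within the scatter, so chloro cannot be told apart from bromo here, nor 3-chlorophenyl from 3,5-dimethylphenyl, and these three compounds have no order among them. Only compound 1 stays apart, and the chloro compound sets out the widest gap seen so far in this small set, a 3.3-fold lower number from compound 1 to compound 4 (0.52 log units; beyond the scatter), which is beyond the scatter yet still modest, so all three other groups give lower numbers than 3-ethylphenyl does. Nothing among the data given explains why these groups give the numbers they do.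

Still open, going by these compounds, is how far this tolerance reaches, since the ring so far carries only halogen and small carbon groups, and an amine, a carboxylic acid or a longer chain in that place could give a very different number. Open too, on these data alone, is whether a 3-fluorophenyl group would stay with compound 2, compound 3 and compound 4.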